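Cyano for methyl on the shared core: extraction notes

The source may report more compounds than this note shows. Statements on the series, on what has been measured and on what is new or still open speak of the compounds shown alone.

Measured so far:
compound 1 `CC(C)(C)n1c(=O)[nH]c2ncc(Br)nc21` — 0.2
compound 2 `O=c1[nH]c2ncc(Br)nc2n1C1CCCCC1` — "not determined" (no result reported)
compound 3 `CCC(CC)n1c(=O)[nH]c2ncc(C)nc21` — < 0.2

Three compounds on the shared core have been run in an ADME assay on microsomes from liver (Homo sapiens), read by LC-MS, with a stated time of 90 min; a lower number here means that the liver removes a smaller share, a higher number that the liver removes a larger share of the compound in one pass. Compound 1 gives 0.2 in this assay. For compound 2 the result is recorded as "not determined" (no result reported), so no number is available. The entry for compound 3 is a limit of the assay rather than a number, < 0.2, and it sits at the limit of < 0.2 in this assay, at which 1 of the 3 values shown sits. Compound 3 therefore stands at the lowest reported end of the series, with one further entry carrying no single number.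

Compound 4 `CCC(CC)n1c(=O)[nH]c2ncc(C#N)nc21` is not yet measured. It differs from compound 3 by cyano in place of methyl on an aromatic carbon. With no measured step of this kind in the series, the expectation is that the step of a number no lower from compound 3 to compound 4 (the limit leaves the size open) stays within the usual scatter, with no direction claimed beyond that. Compound 4 is accordingly estimated at 0.2, with a range from 0.1 to 0.35, and a fair chance that this assay again reports only a limit.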

Compound 4, hepatic extraction ratio: < 0.2
Compound 4: no number, only a limit; the forecaster's own chance of this, stated with the estimate: 40%; the middle value sits exactly at the limit.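

In this assay compound 3 and compound 4 each carry only a limit of the assay, so no step can be read between them: the limit of < 0.2 in this assay, at which 2 of the 4 values shown sit. The compounds shown leave open the size and direction of any difference between cyano and methyl at this place on the shared core.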